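Changing the Group on the Sulfonyl Sulfur of Compound 1

The compounds below may be only part of what the source reports. "The series", "measured", "known", "first", "only" and "open" are said of these compounds alone.

Of the compounds shown here, three sharing one core have been measured in an ADME assay on microsomes from liver (Homo sapiens) for pharmacokinetics, read by LC-MS, with a stated time of 60 min, tested at 1 uM; on this read-out higher numbers stand for fast clearance and lower numbers for slow clearance. Compound 1 `O=C(NCc1ccc(S(=O)(=O)c2cncc(C(F)(F)F)c2)cc1)N1Cc2ccncc2C1` gives 13 mL/min/kg in this assay, and on the numbers shown it stands second highest of the three. Compound 2 `O=C(NCc1ccc(S(=O)(=O)C2CCCCC2)cc1)N1Cc2ccncc2C1` gives 16 mL/min/kg, and compound 3 `CCC(=O)N1CCC(S(=O)(=O)c2ccc(CNC(=O)N3Cc4ccncc4C3)cc2)CC1` gives 11 mL/min/kg. The step of a 1.2-fold higher number from compound 1 to compound 2 (0.09 log units; within the scatter) and the step of a 1.2-fold lower number from compound 1 to compound 3 (0.07 log units; within the scatter) both lie within the scatter, as does the step of a 1.5-fold lower number from compound 2 to compound 3 (0.16 log units; within the scatter). Compound 4 `O=C(NCc1ccc(S(=O)(=O)N2CCC[C@H](O)C2)cc1)N1Cc2ccncc2C1` has not yet been measured in this assay. It differs from compound 1 in one place: 3-hydroxypiperidin-1-yl in place of 5-(trifluoromethyl)pyridin-3-yl on a sulfonyl sulfur. Both measured steps starting from compound 1 bear on this change, as each also exchanged 5-(trifluoromethyl)pyridin-3-yl on the sulfonyl sulfur for a six-membered non-aromatic ring, and neither moved the number beyond the scatter. Compound 4 is therefore expected to show no change at the digits printed from compound 1 to compound 4 (within the scatter), no step beyond the scatter in either direction. The estimate for compound 4 in this assay is 13 mL/min/kg, with a range from 7 mL/min/kg to 25 mL/min/kg.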

Compound 4, clearance: 8 mL/min/kg
The estimate for compound 4 lay 1.6-fold (0.21 log units) above the measured number, and the stated range covers the measured number.
By their numbers in this assay, from the lowest: compounds 4, 3, 1 and 2 (each within the scatter of the next).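

In this assay, the exchange of 5-(trifluoromethyl)pyridin-3-yl for 3-hydroxypiperidin-1-yl, a group that brings a hydrogen-bond donor onto the sulfonyl sulfur, gives a step that stays within the scatter (a 1.6-fold lower number from compound 1 to compound 4 (0.21 log units; within the scatter)). The same holds when the group is set against the two other six-membered non-aromatic rings (a 1.4-fold lower number from compound 3 to compound 4 (0.14 log units; within the scatter)) and (a 2.0-fold lower number from compound 2 to compound 4 (0.30 log units; within the scatter)), so all four groups at this position remain indistinguishable on this read-out. No measurement offered here explains these numbers.

The compounds shown leave open whether any group on the sulfonyl sulfur can move the number beyond the scatter, such as a carboxylic acid, a primary amine or an open-chain alkyl group. They also leave open how the opposite configuration of the 3-hydroxypiperidin-1-yl stereocentre would read.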